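The source may hold more compounds than are shown below. What is called first, only, known or untested is meant among the compounds shown, and "the series" means these compounds.

Working notes on the series. The starting point is compound 1 `Cc1c(C(=O)Nc2ccc(Oc3ncnc4[nH]cc(-c5ccccc5)c34)c(F)c2)c(=O)c2cc(F)ccc2n1C`. In an assay on isolated protein for inhibition of tyrosine-protein kinase receptor UFO (Homo sapiens), read by FRET and Z'-LYTE, with a stated time of 1.5 h (on this read-out lower numbers stand for stronger inhibition and higher numbers for weaker inhibition), compound 1 gives > 10000 nM, which is a limit of the assay and not a measured number, so compound 1 stands at the ceiling of the values shown, as recorded in the limit of > 10000 nM in this assay, at which 1 of the 2 values shown sits. A second measured member of the series is compound 2 `CCc1ccc2c(c1)c(=O)c(C(=O)Nc1ccc(Oc3ncnc4[nH]ccc34)c(F)c1)c(C)n2C`, which differs from compound 1 in more than one place; in this assay compound 2 gives 157 nM. Going by the values given here, no single-point step between the two measured compounds exists, so their values are noted side by side without further reading.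

The next compound to be measured is compound 3 `Cc1c(C(=O)Nc2ccc(Oc3ncnc4[nH]cc(-c5ccccc5)c34)c(F)c2)c(=O)c2cc(C3=CCCC3)ccc2n1C`. Relative to compound 1 the change is cyclopent-1-en-1-yl in place of fluoro on an aromatic carbon, on the aromatic carbon of the bicyclic part of the core that carries the fluoro in compound 1.

With compound 1 known only as a limit, the expected step from compound 1 to compound 3 is estimated at an at least 2.0-fold lower number from compound 1 to compound 3 (0.30 log units; that floor lies within the scatter) in this assay, toward stronger inhibition but of uncertain size. Compound 3 is accordingly expected to give about 5000 nM in this assay, within a range of 800 nM to 30000 nM.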

Compound 3, half-maximal inhibitory concentration: 3320 nM
The estimate for compound 3 lay 1.5-fold (0.18 log units) above the measured number; measured number inside the range.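

Swapping fluoro for cyclopent-1-en-1-yl on this aromatic carbon of the shared core gives, in this assay, an at least 3.0-fold lower number from compound 1 to compound 3 (0.47 log units; beyond the scatter), the first change at this position that can be read, and it lies beyond the scatter. The position therefore tolerates a larger carbon-only substituent with a five-membered non-aromatic ring and a double bond outside aromatic rings, and compound 3 carries a measured number rather than a limit. Compound 1 gives > 10000 nM, which is a limit of the assay and not a number, so the size of this step is only a floor, and the true gap may be larger: the limit of > 10000 nM in this assay, at which 1 of the 3 values shown sits.

As far as these compounds go, it remains open whether the shift follows the ring, the double bond or the carbon count alone, which a saturated cyclopentyl or a straight pentyl chain on the same carbon would help to separate. Also open is how this position responds to substituents containing heteroatoms, such as an amine, a carboxylic acid or a methoxy group, all of which lie outside the compounds shown.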